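The source may report more compounds than this note shows. Statements on the series, on what has been measured and on what is new or still open speak of the compounds shown alone.

Measured so far:

Compound 1, `c1ccc(Cc2[nH]cnc3ncnc2-3)cc1`: 0%
Compound 2, `Fc1ccc(Cc2[nH]cnc3ncnc2-3)cc1`: 3%
Compound 3, `Cn1c(-c2ccc([S+](C)[O-])cc2)nc2c(Sc3ccccc3)ncnc21`: 4%

All three were tested in an assay on isolated protein for inhibition of RAC-alpha serine/threonine-protein kinase (Homo sapiens), tested at 30 uM; a lower number here means less inhibition, a higher number more inhibition at the concentration tested (going by the name of the read-out). Within the data shown here, compound 1 and compound 2 share one core, and the single change between them is fluoro in place of hydrogen on an aromatic carbon. That change produced a number 3 percentage points higher from compound 1 to compound 2 (within the scatter), so the two values are not distinguishable. Compound 3 has a different core; the difference between the two cores is not broken down here. Its value sits nearest to that of compound 2 and furthest from that of compound 1, but both gaps lie within the scatter, so the three numbers are level with one another.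

Compound 4, `Cn1c(-c2ccc([S+](C)[O-])cc2)nc2c(Sc3ccc(F)cc3)ncnc21`, has not yet been measured. It differs from compound 3 by fluoro in place of hydrogen on an aromatic carbon, the same change as from compound 1 to compound 2, made at the same kind of place. Because the earlier instance gave a number 3 percentage points higher from compound 1 to compound 2 (within the scatter), the step from compound 3 to compound 4 is expected to be a number 2 percentage points higher from compound 3 to compound 4 (within the scatter). Compound 4 is therefore estimated at 6% in this assay, likely between -4% and 16%.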

Compound 4, a percentage reported as inhibition, at one concentration (the size of the read-out at that concentration, not a potency): 10%
Compound 4: the middle estimate sits 4 percentage points below what was measured, and the stated range covers the measured number.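

In this assay, fluoro in place of hydrogen, turning phenylsulfanyl into (4-fluorophenyl)sulfanyl, gave a number 6 percentage points higher from compound 3 to compound 4 (within the scatter). Set beside the earlier instance of the change, the new step shows no difference between the two cores: the same change on two cores in this assay, a number 3 percentage points higher (within the scatter) from compound 1 to compound 2 and a number 6 percentage points higher (within the scatter) from compound 3 to compound 4, 3 percentage points apart, within the scatter of two such steps. Both steps lie within the scatter, however, so neither shows that fluoro alters inhibition on its core, and their agreement shows only that no effect of the change could be read on either core, not that a real effect carries from one core to the other.

The compounds shown leave open whether another group on the same aromatic carbon, such as chloro, methoxy or an amine, would give a step beyond the scatter. Also open, going by these compounds, is how the fluoro change would read on a core that gives a much higher number in this assay.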